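A few compounds are considered here, and "the series" means these few. Any claim that something is new, unique, unknown or untested is made for them only; others in the source may bear on it.

The study compares three compounds in a functional assay on SK-OV-3 cells (Homo sapiens) for cytotoxicity, read by sulforhodamine B assay; on this read-out higher numbers stand for weaker inhibition and lower numbers for stronger inhibition. Compound 1 `COc1cc([C@H]2Oc3c(OC)cc(CCCO)cc3[C@@H]2CO[C@@H]2O[C@@H](C)[C@H](O)[C@@H](O)[C@H]2O)cc(OC)c1O` was tested in this assay and returned only a limit, > 10000 nM. Compound 2 `COc1cc(C[C@H]2CO[C@@H](c3cc(OC)c(O)c(OC)c3)[C@H]2CO[C@@H]2O[C@@H](C)[C@H](O)[C@@H](O)[C@H]2O)cc(OC)c1O` likewise reached only the limit of this assay, > 10000 nM. Compound 3 `COc1cc([C@H]2c3c(cc(OC)c(O)c3OC)C[C@@H](CO)[C@@H]2CO[C@@H]2O[C@@H](C)[C@H](O)[C@@H](O)[C@H]2O)cc(OC)c1O` also stopped at the limit in this assay, > 10000 nM. Compound 2 therefore stands nowhere distinct on the numbers shown: every value in this assay is a limit, and (the limit of > 10000 nM in this assay, at which 3 of the 3 values shown sit). Among the measured compounds shown here, with no value measured below the limit, no step between measured compounds can be sized, and nothing among the three compounds separates one from another.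

Compound 4 `COc1cc(C[C@@H]2CO[C@@H](c3cc(OC)c(O)c(OC)c3)[C@@H]2CO[C@@H]2O[C@@H](C)[C@H](O)[C@@H](O)[C@H]2O)cc(OC)c1O` has not yet been measured in this assay. It differs from compound 2 only in configuration: the two compounds have the same atoms and bonds and differ only in configuration as drawn: 2 of 8 stereo elements differ; a stereocentre at a saturated ring carbon is drawn R in compound 2 and S in compound 4; a stereocentre at a saturated ring carbon is drawn R in compound 2 and S in compound 4. For the measured compounds named here, no pair of measured compounds provides a step, so the size of the change from compound 2 to compound 4 in this assay cannot be read from measured differences; the expectation is of no change beyond the scatter, with compound 4 most likely again returning only a limit. Compound 4 is thus expected to give 20000 nM in this assay, within a range from 8000 nM to 100000 nM. The expected step that the limit leaves unreadable from compound 2 to compound 4 is essentially none.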

Compound 4, half-maximal inhibitory concentration: > 10000 nM
Compound 4: no number, only a limit; the forecaster's own chance of this, stated with the estimate: 90%; the middle value lies beyond the limit too.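

Compound 4 returned only a limit in this assay, as compound 2 did, so no step can be read between compound 2 and compound 4, which differ only in configuration as drawn. What the compounds shown leave open is where any of the four would give an actual number in this assay: the limit of > 10000 nM in this assay, at which 4 of the 4 values shown sit.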